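The source may report more compounds than this note shows. Statements on the series, on what has been measured and on what is new or still open speak of the compounds shown alone.

Measured so far:
Compound 1 `Cc1ccc2oc(-c3ccc(NC(=O)CN4CCN(CCN(C)C)CC4)cc3)nc2c1`: 28900 nM
Compound 2 `Cc1ccc2oc(-c3ccc(NC(=O)CN4CCN(CCCN(C)C)CC4)cc3)nc2c1`: 26400 nM
Compound 3 `Cc1cc(-c2nc3cc(F)ccc3o2)ccc1NC(=O)CN1CCN(CCCN(C)C)CC1`: 65700 nM

All three were tested in an ADME assay on NIH3T3 cells (Mus musculus) for cytotoxicity, read by MTT assay, with a stated time of 24 h; a lower number here means a stronger inhibitor, a higher number a weaker inhibitor. Compound 1 and compound 2 share one core and differ only in the chain on the ring amine: going from compound 2 to compound 1 the change is dimethylamino in place of (dimethylamino)methyl on a saturated chain carbon, two bonds along the chain from an amine nitrogen in a ring, and the step it made was a 1.1-fold higher number from compound 2 to compound 1 (0.04 log units; within the scatter). Compound 3 carries a different core; how the core of compound 3 differs from that of compound 2 is not broken down here. In this assay compound 3 gives the highest of the three numbers.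

Compound 4 `Cc1cc(-c2nc3cc(F)ccc3o2)ccc1NC(=O)CN1CCN(CCN(C)C)CC1` has not yet been measured. It stands to compound 3 as compound 1 stands to compound 2: the difference is dimethylamino in place of (dimethylamino)methyl on a saturated chain carbon, two bonds along the chain from an amine nitrogen in a ring, the same change at the same place. The step in this assay that this change is expected to make is a 1.1-fold higher number from compound 3 to compound 4 (0.03 log units; within the scatter), resting on the earlier step of a 1.1-fold higher number from compound 2 to compound 1 (0.04 log units; within the scatter), which stayed within the scatter. For compound 4 the estimated number in this assay is 70000 nM, with a likely range from 35000 nM to 140000 nM.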

Compound 4, half-maximal inhibitory concentration: 62100 nM
Estimate against measurement, compound 4: 1.1-fold (0.05 log units) above; the range from low to high includes it.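

In this assay, replacing 3-(dimethylamino)propyl with 2-(dimethylamino)ethyl on the core of compound 3 gives a 1.1-fold lower number from compound 3 to compound 4 (0.02 log units; within the scatter) and so leaves the number effectively where it was. For the compounds shown here, this agreement shows only that the change made no readable difference on either of these two cores, so it does not show that a step of real size would carry over between them, nor that a third core would behave the same way. The two cores therefore give the same answer for this change, with no sign that the core matters here: the same change on two cores in this assay, a 1.1-fold higher number (0.04 log units; within the scatter) from compound 2 to compound 1 and a 1.1-fold lower number (0.02 log units; within the scatter) from compound 3 to compound 4, 1.2-fold (0.06 log units) apart, within the scatter of two such steps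

The compounds shown leave open whether a longer chain, such as 4-(dimethylamino)butyl, would move the number on either core. They also leave open what would happen if the dimethylamino end were replaced by a carboxylic acid or a hydroxyl group.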